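Lengthening the Ester Chain from Propyl to Butyl

A few compounds are considered here, and "the series" means these few. Any claim that something is new, unique, unknown or untested is made for them only; others in the source may bear on it.

In a functional assay on RAW264.7 cells (Mus musculus) for inhibition (on this read-out lower numbers stand for stronger inhibition and higher numbers for weaker inhibition), compound 3 `CCCOC(=O)C1=CCCCC1S(=O)(=O)Nc1ccc(F)cc1F` gives 29 nM. This lies within the scatter of compound 2 `CCOC(=O)C1=CCCCC1S(=O)(=O)Nc1ccc(F)cc1F` at 16 nM, while compound 1 `CCOC(=O)C1=CCCCC1S(=O)(=O)Nc1cccc(F)c1F` reads a clearly higher 140 nM. Compound 4 `CCCCOC(=O)C1=CCCCC1S(=O)(=O)Nc1ccc(F)cc1F` differs from compound 3 by methyl in place of hydrogen on a saturated chain carbon, three bonds along the chain from an oxygen next to a carbonyl group, taking propyl to butyl. Within the data shown here, one measured step bears on this, the same addition two bonds along the chain, a 1.8-fold higher number from compound 2 to compound 3 (0.26 log units; within the scatter). A small rise within the scatter is therefore expected in this assay, and the expected step is a 1.4-fold higher number from compound 3 to compound 4 (0.14 log units; within the scatter). For compound 4 the estimate is 40 nM, with an expected range of 17 nM to 95 nM.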

Compound 4, half-maximal inhibitory concentration: 140 nM
Compound 4: middle estimate off by 3.5-fold (0.54 log units), on the low side; measured number outside the range, above it.
By their numbers in this assay, from the lowest: compounds 2 and 3 (each within the scatter of the next); then compounds 1 and 4 (each within the scatter of the next).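

Going from propyl to butyl gives a 4.8-fold higher number from compound 3 to compound 4 (0.68 log units; beyond the scatter) in this assay and so shows that this chain position does respond to added length, although the same addition two bonds along the chain stayed within the scatter. Taken together, the two additions amount to an 8.8-fold higher number from compound 2 to compound 4 (0.94 log units; beyond the scatter) and place the clear loss of inhibition at the last carbon added. Nothing available here explains why the change appears at this carbon.

The compounds shown leave open whether a longer chain such as pentyl would raise the number further. They also leave open how a branched chain such as isopropyl, or a carboxylic acid in place of the ester, would read.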